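Chain extension from compound 1: benzyl in place of phenyl

A few compounds are considered here, and "the series" means these few. Any claim that something is new, unique, unknown or untested is made for them only; others in the source may bear on it.

Measured so far:
compound 1, `c1ccc(CC[C@H]2CCCC[C@@H]2NC2=NCCO2)cc1`: 6.92 nM
compound 2, `c1ccc(CCC[C@H]2C3CCC(C3)[C@H]2NC2=NCCO2)cc1`: 141 nM

In an assay on Y-1 cells for inhibition of Alpha-2B adrenergic receptor (Homo sapiens) (on this read-out lower numbers stand for stronger inhibition and higher numbers for weaker inhibition), compound 1 gives 6.92 nM, the lowest of the two numbers recorded. For the measured compounds named here, its nearest neighbour is compound 2, whose value of 141 nM lies well beyond the scatter above it; compound 2 carries a different saturated core, so the pair shows only that the two values differ, not which change drives the gap.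

The untested candidate is compound 3, `c1ccc(CCC[C@H]2CCCC[C@@H]2NC2=NCCO2)cc1`. Relative to compound 1 the change is benzyl in place of phenyl on a saturated chain carbon, two bonds along the chain from a saturated ring carbon; the core of compound 1 is kept.

Going by the values given here, no measured pair isolates this one-carbon lengthening of the chain. Among the compounds with values here, the only compound with the longer chain, compound 2, sits on a different core and gives 141 nM, which hints that the longer chain may cost some potency but does not prove it. A modest loss in this assay is expected, so the step of a 2.9-fold higher number from compound 1 to compound 3 (0.46 log units; beyond the scatter) is estimated to run upward, beyond the scatter but well short of the gap to compound 2. Compound 3 is therefore expected near 20 nM, in the range 5 nM to 80 nM.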

Compound 3, inhibition constant: 32.4 nM
Estimate against measurement, compound 3: 1.6-fold (0.21 log units) below; measured number inside the range.
By their numbers in this assay, from the lowest: compound 1; then compound 3; then compound 2.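

In this assay, benzyl in place of phenyl on a saturated chain carbon, two bonds along the chain from a saturated ring carbon, gives a 4.7-fold higher number from compound 1 to compound 3 (0.67 log units; beyond the scatter). The core of compound 1 is kept in this step, so the longer chain now has a measured cost of its own, which the earlier comparison with a different core could not separate from the core change. The position is therefore sensitive to this change, although the step is modest and no measurement at hand explains its size.

From the compounds shown here alone, both longer-chain compounds carry benzyl, with compound 3 at 32.4 nM and compound 2 at 141 nM, but they differ in the core, and how far that core would affect the phenyl compound remains open. Also open, going by these compounds, are whether a still longer chain raises the number further, and whether a pyridyl ring in place of the phenyl ring, or a fluorine on that ring, changes the effect of the chain in this assay.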